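A few compounds are considered here, and "the series" means these few. Any claim that something is new, unique, unknown or untested is made for them only; others in the source may bear on it.

Of the compounds shown here, three sharing one core have been measured in an ADME assay on HEL cells (Homo sapiens) for cytotoxicity, with a stated time of 3 days; a lower number here means that less compound is tolerated, a higher number that more compound is tolerated. Compound 1 `CCC1(Cc2ccccc2)OS(=O)(=O)C=C1OCC#N` gives only a limit of the assay, > 200000 nM, not a number. Compound 2 `CCC1(Cc2ccccc2)OS(=O)(=O)C=C1OCc1ccccc1Cl` gives 38000 nM, and compound 3 `CC(C)CC1(Cc2ccccc2)OS(=O)(=O)C=C1OCc1ccccc1` gives 102000 nM. One step between compounds differing in a single place has been measured: an at least 5.2-fold lower number from compound 1 to compound 2 (0.72 log units; beyond the scatter). Compound 2 therefore holds the lowest of the two numbers in this assay, with compound 3 standing above it by more than the scatter.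

Compound 4 `CCC1(Cc2ccccc2)OS(=O)(=O)C=C1OCc1ccc(F)cc1` has not yet been measured in this assay. It differs from compound 2 in one place: 4-fluorophenyl in place of 2-chlorophenyl on a saturated chain carbon bound to an oxygen on an unsaturated carbon. For the measured compounds named here, the only measured step, an at least 5.2-fold lower number from compound 1 to compound 2 (0.72 log units; beyond the scatter), exchanged a small polar group for an aryl group, so it bears only loosely on a swap of one halogenated phenyl for another. Compound 4 is therefore expected to stay near compound 2, with a step of a 1.6-fold higher number from compound 2 to compound 4 (0.20 log units; within the scatter) that may lie within the scatter. The estimate for compound 4 in this assay is 60000 nM, between 25000 nM and 150000 nM.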

Compound 4, half-maximal cytotoxic concentration: > 50000 nM
Compound 4 ended at the assay's limit; the forecaster's own chance of this, stated with the estimate: 10%; the middle value lies beyond the limit too.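

In this assay compound 4 gives only a limit of the assay, not a number: the limit of > 50000 nM in this assay, at which 1 of the 4 values shown sits. Putting 4-fluorophenyl in place of 2-chlorophenyl, on a saturated chain carbon bound to an oxygen on an unsaturated carbon, gives an at least 1.3-fold higher number from compound 2 to compound 4 (0.11 log units; that floor lies within the scatter), so this change may be small or much larger, and the data do not yet show that it matters at all. The step between compound 1 and compound 4 cannot be read, as both values are limits.

Compound 2 and compound 4 differ in both the halogen and its ring position, and a 4-chlorophenyl group, sharing its halogen with compound 2 and its ring position with compound 4, would help to separate the two. Also open, on these data alone, is how a group carrying an amine would behave at this place.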